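Swapping thiophene for phenyl beside the ring nitrogen

A few compounds are considered here, and "the series" means these few. Any claim that something is new, unique, unknown or untested is made for them only; others in the source may bear on it.

compound 1, `Oc1ccc(-c2cc(-c3ccc(Cl)cc3)nc(-c3cccnc3)c2)cc1`: 29300 nM
compound 2, `Oc1ccc(-c2cc(-c3ccc(Cl)cc3)nc(-c3cccs3)c2)cc1`: 6450 nM
compound 3, `Oc1ccc(-c2cc(-c3cccc(Cl)c3)nc(-c3cccs3)c2)cc1`: 5350 nM

In a functional assay on T47D cells (Homo sapiens) for cytotoxicity, read by CCK-8 assay and cell counting, with a stated time of 2 days (on this read-out lower numbers stand for stronger inhibition and higher numbers for weaker inhibition), compound 2 stands second highest of the three numbers; compound 3 is its nearest neighbour, with a 1.2-fold lower number from compound 2 to compound 3 (0.08 log units; within the scatter), and compound 1 its furthest, with a 4.5-fold lower number from compound 1 to compound 2 (0.66 log units; beyond the scatter). Compound 4, `Oc1ccc(-c2cc(-c3ccccc3)nc(-c3ccc(Cl)cc3)c2)cc1`, differs from compound 2 in one place: phenyl in place of thiophen-2-yl on an aromatic carbon. For the measured compounds named here, the one step that bears on this position is the one from compound 1 to compound 2, which removed a ring nitrogen acceptor and was modest but beyond the scatter. Removing the sulfur acceptor is expected to do little, so in this assay compound 4 is expected to give 5000 nM, between 2000 nM and 15000 nM, a step of a 1.3-fold lower number from compound 2 to compound 4 (0.11 log units; within the scatter) that is expected to stay within the scatter.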

Compound 4, half-maximal inhibitory concentration: 4270 nM
Compound 4: the middle estimate sits 1.2-fold (0.07 log units) above what was measured; the range from low to high includes it.
By their numbers in this assay, from the lowest: compounds 4, 3 and 2 (each within the scatter of the next); then compound 1.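

In this assay, a ring of carbon only serves at this position as well as the thiophen-2-yl group does (a 1.5-fold lower number from compound 2 to compound 4 (0.18 log units; within the scatter)). The pyridin-3-yl group alone stands apart among the three groups tried here, since phenyl also differs from it beyond the scatter (a 6.9-fold lower number from compound 1 to compound 4 (0.84 log units; beyond the scatter)). Nothing at hand accounts for this difference.

On these data alone, what a saturated amine such as piperidine or a carboxylic acid would do in this place remains open. So does whether phenyl matches thiophen-2-yl when 3-chlorophenyl is the partner group.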